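From isopropylsulfonyl to cyclobutylcarbonyl on the same oxygen

The compounds below may be only part of what the source reports. "The series", "measured", "known", "first", "only" and "open" are said of these compounds alone.

Three compounds share a core and differ in the group carried on one oxygen: compound 1 `Cc1cccc(C(=O)OC2CCC(CN3CCN(c4cc(=O)c5cc(C(F)(F)F)cc([N+](=O)[O-])c5s4)CC3)CC2)c1`, compound 2 `CCCC(=O)OC1CCC(CN2CCN(c3cc(=O)c4cc(C(F)(F)F)cc([N+](=O)[O-])c4s3)CC2)CC1` and compound 3 `CC(C)S(=O)(=O)OC1CCC(CN2CCN(c3cc(=O)c4cc(C(F)(F)F)cc([N+](=O)[O-])c4s3)CC2)CC1`. All three were tested in an ADME assay on Vero cells (Chlorocebus sabaeus) for cytotoxicity, read by MTT assay, with a stated time of 48 h; on this read-out higher numbers stand for weaker inhibition and lower numbers for stronger inhibition. Compound 1 gives > 64 ug/mL, which is a limit of the assay. Compound 2 gives > 64 ug/mL, again a limit. Compound 3 gives > 64 ug/mL, likewise a limit, so it has no exact number of its own.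

Compound 4 `O=C(OC1CCC(CN2CCN(c3cc(=O)c4cc(C(F)(F)F)cc([N+](=O)[O-])c4s3)CC2)CC1)C1CCC1` is the next to be measured. It carries cyclobutylcarbonyl in place of isopropylsulfonyl on an oxygen on a saturated carbon.

The closest measured comparison is a step that the two limits leave unreadable from compound 2 to compound 3, since it also exchanges isopropylsulfonyl and a carbonyl group. The others are a step that the two limits leave unreadable from compound 1 to compound 3 and a step that the two limits leave unreadable from compound 1 to compound 2. None of these steps has a size that can be read. The firm observation is the limit of > 64 ug/mL in this assay, at which 3 of the 3 values shown sit. Because compound 3 shares (the limit of > 64 ug/mL in this assay, at which 3 of the 3 values shown sit), no step beyond the usual scatter is expected for compound 4, in either direction, and another limit is the likeliest report. The expected change is a step that the limit leaves unreadable from compound 3 to compound 4. For compound 4 the estimate is 90 ug/mL, with an expected range from 45 ug/mL to 180 ug/mL.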

Compound 4, half-maximal inhibitory concentration: > 64 ug/mL
Compound 4 gave a limit, no number (the forecaster's own chance of this, stated with the estimate: 90%); the middle value does not contradict the limit.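

No step to compound 4 from compound 1, compound 2 or compound 3 can be read, since all four compounds give only a limit and not a number: the limit of > 64 ug/mL in this assay, at which 4 of the 4 values shown sit.

The compounds shown leave open what concentration of any of them would give half-maximal inhibition in this assay, and so how the groups on this oxygen compare.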